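Removing the bromo from compound 3: an expected small shift

The source may report more compounds than this note shows. Statements on the series, on what has been measured and on what is new or still open speak of the compounds shown alone.

Three analogues built on one shared core have been tested in a functional assay on MCF7 cells (Homo sapiens) for cytotoxicity, read by sulforhodamine B assay, with a stated time of 48 h; a higher number here means a weaker inhibitor of growth, a lower number a stronger inhibitor of growth. Compound 1 `NC(=S)N/N=C1/C(=O)N(CN2CCN(c3ccnc4cc(Cl)ccc34)CC2)c2ccccc21` gives 23000 nM. Compound 2 `NC(=S)N/N=C1/C(=O)N(CN2CCN(c3ccnc4cc(C(F)(F)F)ccc34)CC2)c2cccc(Cl)c21` gives 21600 nM. Compound 3 `NC(=S)N/N=C1/C(=O)N(CN2CCN(c3ccnc4cc(C(F)(F)F)ccc34)CC2)c2cc(Br)ccc21` gives 35500 nM, the highest of the three numbers, although its gaps to compound 1 and to compound 2 both lie within the usual scatter, so no ranking among the three can be claimed. Compound 4 `NC(=S)N/N=C1/C(=O)N(CN2CCN(c3ccnc4cc(C(F)(F)F)ccc34)CC2)c2ccccc21` differs from compound 3 only by hydrogen in place of bromo on an aromatic carbon. Going by the values given here, no measured pair shows this change, so the expectation rests on compound 1, which also carries hydrogen rather than bromo at that place and gives 23000 nM. Compound 4 is therefore expected to give 25000 nM, between 12000 nM and 52000 nM. The expected step from compound 3 to compound 4, a 1.4-fold lower number from compound 3 to compound 4 (0.15 log units; within the scatter), is small, toward a lower number, and not beyond the scatter.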

Compound 4, concentration for 50% growth inhibition: 13900 nM
Compound 4: middle estimate off by 1.8-fold (0.25 log units), on the high side; measured number inside the range.
By their numbers in this assay, from the lowest: compounds 4, 2, 1 and 3 (each within the scatter of the next, the first and the last beyond it).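

In this assay, going by these compounds alone, the change from bromo to hydrogen on this aromatic carbon gives the first step beyond the scatter (a 2.6-fold lower number from compound 3 to compound 4 (0.41 log units; beyond the scatter)). The two other changes stay within the scatter: chloro giving way to hydrogen (a 1.6-fold lower number from compound 2 to compound 4 (0.19 log units; within the scatter)) and trifluoromethyl in place of chloro on an aromatic carbon (a 1.7-fold lower number from compound 1 to compound 4 (0.22 log units; within the scatter)). No evidence is available to explain these steps. The compounds shown leave open how an amine or a carboxylic acid on this aromatic carbon would compare with hydrogen and bromo.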